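Methyl in Place of Trifluoromethyl on an Aromatic Carbon

The source may hold more compounds than are shown below. What is called first, only, known or untested is meant among the compounds shown, and "the series" means these compounds.

Of the compounds shown here, two with a shared core have numbers so far. In a functional assay on BXPC-3 cells (Homo sapiens) for inhibition, read by MTT assay (on this read-out higher numbers stand for weaker inhibition and lower numbers for stronger inhibition), compound 1 `COc1ccc(NC(=O)c2cc3cnc(Nc4ccc(N5CCNCC5)cn4)nc3n2C2CCCC2)cc1` gives 8970 nM. In this assay, compound 2 `O=C(Nc1ccccc1C(F)(F)F)c1cc2cnc(Nc3ccc(N4CCNCC4)cn3)nc2n1C1CCCC1` gives 8040 nM, so the two stand level within the scatter of repeated measurements.

Among the compounds with values here, the only measured step is a 1.1-fold lower number from compound 1 to compound 2 (0.05 log units; within the scatter). It puts 2-(trifluoromethyl)phenyl in place of 4-methoxyphenyl on an amide-type nitrogen.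

The next compound, compound 3 `Cc1ccccc1NC(=O)c1cc2cnc(Nc3ccc(N4CCNCC4)cn3)nc2n1C1CCCC1`, keeps all of compound 2 except one group: methyl in place of trifluoromethyl on an aromatic carbon. This is methyl in place of trifluoromethyl on an aromatic carbon, ortho to a large group. Within the data shown here, no measured pair shows this exact swap, so the evidence is thin. The closest guide is the step of a 1.1-fold lower number from compound 1 to compound 2 (0.05 log units; within the scatter), which changed the same aromatic group and stayed within the scatter. On that single step, no shift beyond the scatter is expected in this assay, and no direction can be favoured. The expected step is a 1.0-fold lower number from compound 2 to compound 3 (0.00 log units; within the scatter). For compound 3 the estimated value is 8000 nM, with an expected range of 4500 nM to 14000 nM.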

Compound 3, half-maximal inhibitory concentration: 3340 nM
The estimate for compound 3 lay 2.4-fold (0.38 log units) above the measured number, outside the stated range (below it).
By their numbers in this assay, from the lowest: compound 3; then compounds 2 and 1 (each within the scatter of the next).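

In this assay, methyl in place of trifluoromethyl gives a 2.4-fold lower number from compound 2 to compound 3 (0.38 log units; beyond the scatter) and so moves the number beyond the scatter, which shows that the group on this aromatic carbon can matter. The earlier pair could not show this: the step of a 1.1-fold lower number from compound 1 to compound 2 (0.05 log units; within the scatter) stayed within the scatter, and that level result might have suggested that the aromatic group on the amide nitrogen made little difference on this read-out. The 2-methylphenyl group also stands apart from 4-methoxyphenyl, with a 2.7-fold lower number from compound 1 to compound 3 (0.43 log units; beyond the scatter) as a modest step, but nothing measured here explains why methyl goes with the lower number.

As far as these compounds go, with only methyl and trifluoromethyl compared on this carbon, it remains open whether a chlorine atom, an ethyl group or a methoxy group would track with methyl, with trifluoromethyl or with neither. A plain phenyl group carrying nothing on this carbon would also be needed to tell whether methyl lowers the number or trifluoromethyl simply fails to do so.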